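Extending the Alkyl Chain Further on Compound 3

A few compounds are considered here, and "the series" means these few. Any claim that something is new, unique, unknown or untested is made for them only; others in the source may bear on it.

Three ureas sharing one core have been measured in an ADME assay on the whole organism with Oryza sativa as the target, tested at 1 uM; a lower number here means a stronger effect, a higher number a weaker effect of the compound at the concentration tested. Compound 1 `CC(C)c1ccc(NC(=O)N[C@H](C)c2ccccc2)cc1` gives 79%. Compound 2 `CCCc1ccc(NC(=O)N[C@H](C)c2ccccc2)cc1` gives 31%, and compound 3 `CCCCc1ccc(NC(=O)N[C@H](C)c2ccccc2)cc1` gives 32%. On these numbers compound 3 stands second highest of the three: nearest to it is compound 2, with a number 1 percentage points higher from compound 2 to compound 3 (within the scatter), and furthest is compound 1, with a number 47 percentage points lower from compound 1 to compound 3 (beyond the scatter). Compound 4 `CCCCCCCc1ccc(NC(=O)N[C@H](C)c2ccccc2)cc1` differs from compound 3 by propyl in place of hydrogen on a saturated chain carbon, four bonds along the chain from an aromatic carbon. The step bearing most on this change is the earlier chain lengthening, a number 1 percentage points higher from compound 2 to compound 3 (within the scatter); the large steps of a number 48 percentage points lower from compound 1 to compound 2 (beyond the scatter) and a number 47 percentage points lower from compound 1 to compound 3 (beyond the scatter) concern a change of branching rather than of length. Hence no step beyond the scatter is expected in this assay, and compound 4 is estimated at 32%, between 14% and 55%, an expected step of no change at the digits printed from compound 3 to compound 4 (within the scatter).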

Compound 4, a percentage reported as activity, at one concentration (the size of the read-out at that concentration, not a potency): 100%
Compound 4: middle estimate off by 68 percentage points, on the low side; the whole stated range lies below it.
By their numbers in this assay, from the lowest: compounds 2 and 3 (each within the scatter of the next); then compound 1; then compound 4.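

In this assay, lengthening the straight chain at this position is not neutral throughout: adding propyl in place of hydrogen, four bonds along the chain from an aromatic carbon, weakens the effect sharply (a number 68 percentage points higher from compound 3 to compound 4 (beyond the scatter)), and the step from the shorter chain is similar (a number 69 percentage points higher from compound 2 to compound 4 (beyond the scatter)). Heptyl also ends up weaker than the branched isopropyl (a number 21 percentage points higher from compound 1 to compound 4 (beyond the scatter)), so branching is not the only change that can weaken the effect here. No available evidence accounts for this reversal. Still open, on these data alone, is where the loss sets in, which a pentyl or hexyl group at this position would show. Also open, as far as these compounds go, is whether a heptyl chain ending in a carboxylic acid would behave alike.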